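This account rests on a few compounds, and the source may have more. Where it says the series, first, only, none or still open, it means among the compounds named here.

Compound 1, `CCCCCCCCc1cn(Cc2cc(=O)oc3cc(O)ccc23)nn1`, in a functional assay on CFPAC-1 cells (Homo sapiens) for inhibition, read by MTT assay, with a stated time of 72 h (a higher number here means a weaker inhibitor, a lower number a stronger inhibitor), gives 62700 nM.
Compound 2, `O=c1cc(Cn2cc(CCc3ccccc3)nn2)c2ccc(O)cc2o1`, in this assay gives only a limit of the assay, > 100000 nM.
Compound 3, `O=c1cc(Cn2cc(CNS(=O)(=O)c3ccc(F)cc3)nn2)c2ccc(O)cc2o1`, in this assay gives only a limit of the assay, > 100000 nM.

All three share one core, and the side chain on its triazole is what varies. Within the data shown here, the only step with two real numbers, an at least 1.5-fold higher number from compound 1 to compound 2 (0.20 log units; that floor lies within the scatter), starts from a weak inhibitor and ends at a limit. Going by these compounds, compound 3 stands at that same limit, (the limit of > 100000 nM in this assay, at which 2 of the 3 values shown sit), so its true value is unknown beyond being at or past the cut-off.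

The new compound, compound 4, `O=c1cc(Cn2cc(CNS(=O)(=O)c3ccc([N+](=O)[O-])cc3)nn2)c2ccc(O)cc2o1`, changes only the group on the sulfonyl-bearing ring: nitro in place of fluoro on an aromatic carbon. Among the measured compounds shown here, no measured step touches this part of the molecule, so none bears on the change directly. What the numbers show is that the sulfonamide series sits at the limit, and nothing measured suggests that a swap of one small aromatic substituent would move it into the measurable range. Compound 4 is therefore expected to remain near or beyond the limit, with an estimated step of a number no higher from compound 3 to compound 4 (the limit leaves the size open) and an estimate of 100000 nM, between 40000 nM and 300000 nM.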

Compound 4, half-maximal inhibitory concentration: > 100000 nM
Compound 4 gave a limit, no number; the forecaster's own chance of this, stated with the estimate: 80%; the middle value sits exactly at the limit.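

Compound 4 gives only a limit in this assay, > 100000 nM. Among these compounds, compound 3 also gives only a limit, so no step between the two can be read. The compounds shown leave open how far past the limit each true value lies, and whether nitro in place of fluoro changes inhibition at all.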